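Replacing a methoxymethyl chain with a hydroxyethyl amide tail

The source may report more compounds than this note shows. Statements on the series, on what has been measured and on what is new or still open speak of the compounds shown alone.

Measured compounds:
compound 1, `COCC[C@@H]1C[C@@H](c2ccc(Cl)c(Cl)c2)[C@H](NC(=O)c2cc(-c3c(Cl)cnn3C)c(Cl)o2)CN1`: 470 nM
compound 2, `Cn1ncc(Cl)c1-c1cc(C(=O)N[C@@H]2CN[C@H](CC(O)CO)C[C@H]2c2ccc(F)c(F)c2)oc1Cl`: 800 nM

Both compounds were tested in a functional assay on HCT-116 cells (Homo sapiens) for antiproliferative activity, read by sulforhodamine B assay, with a stated time of 72 h; a higher number here means a weaker inhibitor, a lower number a stronger inhibitor. In this assay compound 1 gives 470 nM, and compound 2 gives 800 nM. These two numbers lie within the usual scatter of each other, so neither compound can be set apart from the other on this evidence.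

Compound 3, `Cn1ncc(Cl)c1-c1cc(C(=O)N[C@@H]2CN[C@H](CC(=O)NCCO)C[C@H]2c2ccc(Cl)c(Cl)c2)oc1Cl`, has not yet been measured. It differs from compound 1 in one place:

(2-hydroxyethyl)carbamoyl in place of methoxymethyl on a saturated chain carbon bound to a saturated ring carbon

Among the compounds with values here, no pair of measured compounds differs by this kind of change, so there is no measured step to lean on. The expectation is a small step from compound 1 to compound 3, a 1.4-fold higher number from compound 1 to compound 3 (0.14 log units; within the scatter), toward a slightly higher number, most likely not beyond the scatter. Compound 3 is therefore estimated at 650 nM, with a range from 250 nM to 1700 nM.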

Compound 3, half-maximal inhibitory concentration: 670 nM
Compound 3: middle estimate off by 1.0-fold (0.01 log units), on the low side; the measured number falls inside the stated range.
By their numbers in this assay, from the lowest: compounds 1, 3 and 2 (each within the scatter of the next).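

In this assay, within the data shown here, putting (2-hydroxyethyl)carbamoyl in place of methoxymethyl gives a 1.4-fold higher number from compound 1 to compound 3 (0.15 log units; within the scatter), the only measured step at this position. The result shows that, on the core of compound 1, a group of 6 heavy atoms with 2 hydrogen-bond donors can replace one of 3 heavy atoms with 0 donors on this saturated chain carbon, and the number stays within the scatter. Nothing measured here explains this outcome.

The compounds shown leave open whether a carboxylic acid or an amine in place of methoxymethyl would also stay within the scatter of compound 1. They also leave open whether a longer chain ending in the same hydroxyethyl amide would do so.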